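Swapping One Halogen for Another on the Carboxyphenyl Tail

The source may report more compounds than this note shows. Statements on the series, on what has been measured and on what is new or still open speak of the compounds shown alone.

Measured compounds:
compound 1 `Cc1c(OCCCCOc2ccc(F)c(C(=O)O)c2)ccc(C(=O)CC2CCCC2)c1O` — 81%
compound 2 `Cc1cc(OCCCCOc2ccc(C(=O)CC3CCCC3)c(O)c2C)ccc1C(=O)O` — 83.6%
compound 3 `Cc1c(OCCCCOc2ccc(C(=O)O)cc2F)ccc(C(=O)CC2CCCC2)c1O` — 83.8%

All three numbers come from an assay on HEK293 cells for positive allosteric modulation of metabotropic glutamate receptor 2 (Rattus norvegicus), read by thallium flux, with a stated time of 2.5 min; on this read-out lower numbers stand for smaller maximal responses and higher numbers for larger maximal responses. The three compounds share one core and differ only in the aryl group that hangs on an oxygen on a saturated carbon at the far end of the chain. Their values sit close together: the change a number 2.6 percentage points higher from compound 1 to compound 2 (within the scatter) and the change a number 2.8 percentage points higher from compound 1 to compound 3 (within the scatter) are both within the scatter, and compound 3 is separated from compound 2 by only a number 0.2 percentage points higher from compound 2 to compound 3 (within the scatter). So compound 3 gives the largest of the three numbers, but nothing in these data sets it apart from the others.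

Compound 4 `Cc1c(OCCCCOc2ccc(C(=O)O)c(Cl)c2)ccc(C(=O)CC2CCCC2)c1O` carries the change (4-carboxy-3-chlorophenyl in place of 4-carboxy-2-fluorophenyl on an oxygen on a saturated carbon). It is again a swap of substituents on the same carboxyphenyl tail, and every measured step of that kind, whether moving a carboxy group, exchanging fluorine for methyl, or shifting a fluorine, stayed within the scatter. On that basis the step of a number 0.8 percentage points lower from compound 3 to compound 4 (within the scatter) is expected to be no larger than the scatter, in no particular direction. Compound 4 is therefore estimated to give about 83%, with a likely range from 74% to 92%.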

Compound 4, largest response reached (reported as percent of maximum), in percent of the reference or control that the assay uses: 80.8%
Beside the measured number, compound 4's estimate is 2.2 percentage points above it; low and high end bracket the measured number.
By their numbers in this assay, from the lowest: compounds 4, 1, 2 and 3 (each within the scatter of the next).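

In this assay the exchange of fluorine for chlorine on the tail, which also shifts the halogen's place on the ring, brings a number 3 percentage points lower from compound 3 to compound 4 (within the scatter) and so leaves the maximal response unchanged within the usual spread of repeat measurements. Chloro in place of methyl on an aromatic carbon gives a number 2.8 percentage points lower from compound 2 to compound 4 (within the scatter) and the comparison with the tail of compound 1 gives a number 0.2 percentage points lower from compound 1 to compound 4 (within the scatter) so at this position, on an oxygen on a saturated carbon, chlorine now joins fluorine and methyl among the tail substituents, and all four compounds stand within the scatter of one another. Nothing available here offers an explanation for this lack of response to the tail's substituents.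

Every tail shown carries a carboxylic acid, so the compounds leave open what a tetrazole or a primary amide in its place would give. They also leave open whether the response stays this flat with a trifluoromethyl or methoxy group on the same ring, or with a longer chain joining the tail to the shared core.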